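Oxadiazole for trifluoromethyl: half-life read-across to compound 4

The source may report more compounds than this note shows. Statements on the series, on what has been measured and on what is new or still open speak of the compounds shown alone.

Measured so far in an in vivo ADME assay on the whole organism (strain Sprague-Dawley) for metabolic stability, with Rattus norvegicus as the target, at a dose of 2 mg/kg by the intravenous route; a higher number here means that the compound lasts longer, a lower number that the compound disappears faster:
- compound 1 `C[C@@H](Nc1nccc(Cl)c1NC(=O)CC#N)c1ccc(-c2cccc(F)c2C(F)(F)F)cc1`: 1.8 h
- compound 2 `Cc1noc(-c2c(F)cccc2-c2ccc([C@@H](C)Nc3nccc(Cl)c3NC(=O)CC#N)cc2)n1`: 8.8 h
- compound 3 `COC(=O)c1ccc(Cl)cc1-c1ccc([C@@H](C)Nc2nccc(Cl)c2NC(=O)CC#N)cc1`: 0.5 h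

Compound 1 stands second highest of the three numbers in this assay; its nearest neighbour is compound 3, the furthest is compound 2. Compound 2 carries a five-membered aromatic ring where compound 1 has trifluoromethyl, and this assay rose by a 4.9-fold higher number from compound 1 to compound 2 (0.69 log units; beyond the scatter). Compound 3 replaces the whole biaryl fragment, and this assay fell by a 3.6-fold lower number from compound 1 to compound 3 (0.56 log units; beyond the scatter).

Compound 4 `Cc1nc(-c2c(F)cccc2-c2ccc([C@@H](C)Nc3nccc(Cl)c3NC(=O)CC#N)cc2)no1` is not yet measured. It differs from compound 1 by 5-methyl-1,2,4-oxadiazol-3-yl in place of trifluoromethyl on an aromatic carbon. The change is the regioisomer of the one made in going to compound 2, the same ring attached through its other carbon, with the methyl on the remaining carbon. Within the data shown here, only the step to compound 2 bears on it; the step to compound 3 concerns a different part of the molecule. The expectation is therefore a modest rise in this assay, in the same direction as with compound 2, with some allowance for the different attachment, expected step a 3.3-fold higher number from compound 1 to compound 4 (0.52 log units; beyond the scatter). Compound 4 is thus estimated at 6 h, range 2.5 h to 14 h.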

Compound 4, half-life: 12.9 h
The estimate for compound 4 lay 2.2-fold (0.33 log units) below the measured number; the range from low to high includes it.
By their numbers in this assay, from the lowest: compound 3; then compound 1; then compounds 2 and 4 (each within the scatter of the next).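

In this assay the change to 5-methyl-1,2,4-oxadiazol-3-yl in place of trifluoromethyl, on the aromatic carbon ortho to a fluoro group, gives a 7.2-fold higher number from compound 1 to compound 4 (0.86 log units; beyond the scatter) and so shows that the rise seen with compound 2 does not depend on one attachment of the ring. The two regioisomers cannot be told apart at this position, since the swap gives a 1.5-fold higher number from compound 2 to compound 4 (0.17 log units; within the scatter) and stays within the scatter. Nothing available accounts for the rise over trifluoromethyl.

From the compounds shown here alone, how an amine or a longer chain in place of the methyl on the oxadiazole would affect the half-life remains open. Also open, going by these compounds, is whether the rise requires the five-membered aromatic ring at all, which a carboxamide on the same aromatic carbon could test.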